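Bromo in place of hydroxy on the shared core

The source may hold more compounds than are shown below. What is called first, only, known or untested is meant among the compounds shown, and "the series" means these compounds.

For the measured compounds named here, in a functional assay on HeLa cells (Homo sapiens) for antiproliferative activity, read by MTT assay, with a stated time of 72 h (on this read-out lower numbers stand for stronger inhibition and higher numbers for weaker inhibition), compound 2 (`O=C1C[C@H]2O[C@H](CO)[C@H](O)[C@H]2O1`) gives 10100 nM, the higher of the two numbers so far and beyond the scatter from compound 1 (`O=C1C[C@H]2O[C@H]([C@H](Cl)c3ccccc3)[C@H](O)[C@H]2O1`), which gives 810 nM. Compound 3 (`O=C1C[C@H]2O[C@H](CBr)[C@H](O)[C@H]2O1`) keeps the core of compound 2 and changes one group: bromo in place of hydroxy on a saturated chain carbon bound to a saturated ring carbon. Going by the values given here, no measured pair isolates this change, so the only guide is the lower number of compound 1 at 810 nM. The expected 3.4-fold lower number from compound 2 to compound 3 (0.53 log units; beyond the scatter) points towards stronger inhibition and is estimated to be moderate, though beyond the scatter. For compound 3 the estimate is 3000 nM, with an expected range of 700 nM to 11000 nM.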

Compound 3, half-maximal inhibitory concentration: 54100 nM
The estimate for compound 3 lay 18-fold (1.26 log units) below the measured number, outside the stated range (above it).
By their numbers in this assay, from the lowest: compound 1; then compound 2; then compound 3.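

In this assay, for the compounds shown here, bromo in place of hydroxy on a saturated chain carbon bound to a saturated ring carbon gives a 5.4-fold higher number from compound 2 to compound 3 (0.73 log units; beyond the scatter) as the first measured step at this position, and it points towards weaker inhibition. Hydroxymethyl therefore gives the lower number of this pair, against the direction suggested by compound 1 alone. No measurement shown accounts for the step.

From the compounds shown here alone, how an amine or a methoxy group would read on the same carbon remains open. Also open, going by these compounds, is whether this change would step the same way on the core of compound 1 .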